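A few compounds are considered here, and "the series" means these few. Any claim that something is new, unique, unknown or untested is made for them only; others in the source may bear on it.

This study concerns four related compounds and how they behave in a functional assay on THP-1 cells (Homo sapiens) for cytotoxicity, read by MTT assay, with a stated time of 24 h; a higher number here means a weaker inhibitor, a lower number a stronger inhibitor. Compound 1 has the structure `Cc1ccc(-c2nnc(SCCCN3CCN(c4cccc(Cl)c4)CC3)[nH]2)cc1`. In this assay compound 1 gives > 300000 nM, which is a limit of the assay and not a number. Compound 2, with the structure `Clc1ccc(-c2nnc(SCCCN3CCN(c4cccc(Cl)c4)CC3)[nH]2)cc1`, differs from compound 1 by chloro in place of methyl on an aromatic carbon. In this assay compound 2 gives > 300000 nM, again a limit rather than a number. The change from compound 1 to compound 2 therefore made a step that the two limits leave unreadable from compound 1 to compound 2. Compound 3 has the structure `Cc1ccc(-c2nn(CCCN3CCN(c4cccc(Cl)c4)CC3)c(=S)[nH]2)cc1`; it is built from the same atoms as compound 1, joined differently, and the difference between the two cores is not broken down here. In this assay compound 3 gives > 300000 nM, which is once more a limit. What the three measured values have in common is the limit of > 300000 nM in this assay, at which 3 of the 3 values shown sit.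

Compound 4, with the structure `S=c1[nH]c(-c2ccc(Cl)cc2)nn1CCCN1CCN(c2cccc(Cl)c2)CC1`, has not yet been measured. It differs from compound 3 by chloro in place of methyl on an aromatic carbon, the same change that separates compound 1 from compound 2, made at a place described in the same words. The step is expected to be small, because the earlier instance of this change made a step that the two limits leave unreadable from compound 1 to compound 2 and both of its ends sat at the limit. The step from compound 3 to compound 4 is expected to be a step that the limit leaves unreadable from compound 3 to compound 4. Compound 4 is therefore estimated at 500000 nM, with a likely range from 200000 nM to 2000000 nM, and this assay will most probably report only a limit for it.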

Compound 4, half-maximal inhibitory concentration: > 300000 nM
Compound 4 gave a limit, no number; the forecaster's own chance of this, stated with the estimate: 85%; the middle value is on the limit's open side.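

Within the data shown here, compound 3 and compound 4 both sit at a limit of the assay rather than at a number, so no step between them can be read, and the whole set shares this position: the limit of > 300000 nM in this assay, at which 4 of the 4 values shown sit. The compounds shown leave open whether the change from 4-methylphenyl to 4-chlorophenyl, or the difference between the two cores, alters the true strength of these compounds in this assay at all.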